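Three amides at one cytotoxicity limit, a fourth awaited

The compounds below may be only part of what the source reports. "The series", "measured", "known", "first", "only" and "open" are said of these compounds alone.

Compound 1 `COc1ccccc1CNC(=O)CSc1c[nH]c2ccc(Br)cc12`: > 100000 nM
Compound 2 `O=C(CSc1c[nH]c2ccc(Br)cc12)NCc1ccc(Cl)c(Cl)c1`: > 100000 nM
Compound 3 `COc1ccccc1CNC(=O)CSc1c[nH]c2cc(Br)ccc12`: > 100000 nM

Of the compounds shown here, three have been measured in an ADME assay on HEK-293T cells (Homo sapiens) for cytotoxicity, read by CCK-8 assay, with a stated time of 24 h; a lower number here means that less compound is tolerated, a higher number that more compound is tolerated. Compound 1 gives > 100000 nM in this assay, which is a limit of the assay and not a number. Compound 2 likewise gives > 100000 nM in this assay, again a limit. Compound 3 gives > 100000 nM in this assay, also a limit. All three values therefore sit at the limit of > 100000 nM in this assay, at which 3 of the 3 values shown sit.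

Compound 1 and compound 2 share a core and differ by 3,4-dichlorophenyl in place of 2-methoxyphenyl on a saturated chain carbon bound to an amide-type nitrogen. The step that the two limits leave unreadable from compound 1 to compound 2 cannot be read, since both ends are limits. Compound 3 has the same atoms as compound 1, joined differently; how the two cores differ is not broken down here.

Compound 4 `O=C(CSc1c[nH]c2cc(Br)ccc12)NCc1ccc(Cl)c(Cl)c1` has not yet been measured. It differs from compound 3 by 3,4-dichlorophenyl in place of 2-methoxyphenyl on a saturated chain carbon bound to an amide-type nitrogen, the same change that separates compound 1 from compound 2, at the same place. The expected step from compound 3 to compound 4 in this assay is estimated as a number no higher from compound 3 to compound 4 (the limit leaves the size open), because compound 1, compound 2 and compound 3 all sit at the limit of > 100000 nM in this assay, at which 3 of the 3 values shown sit. Compound 4 is accordingly expected to give about 100000 nM in this assay, somewhere between 50000 nM and 300000 nM, most likely reported only as a limit.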

Compound 4, half-maximal cytotoxic concentration: 67600 nM
Compound 4: middle estimate off by 1.5-fold (0.17 log units), on the high side; measured number inside the range.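

In this assay, going by these compounds alone, compound 4 gives 67600 nM, the only value of the four that is not a limit. Putting 3,4-dichlorophenyl in place of 2-methoxyphenyl on the core of compound 3 amounts to an at least 1.4-fold lower number from compound 3 to compound 4 (0.17 log units; that floor lies within the scatter), which is a floor and not a measured size. Compound 3 gives > 100000 nM, which is a limit of the assay and not a number. The same change on the core of compound 1 cannot be read, so these compounds do not show whether the change carries from one core to the other, neither confirming nor ruling out a matching step, and the ceiling that hides the comparison is shared by most of the values shown: the limit of > 100000 nM in this assay, at which 3 of the 4 values shown sit.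

Going by these compounds, what remains open is how far below the ceiling the other three compounds would fall if they could be read, and whether the number for compound 4 is tied to the 3,4-dichlorophenyl group, to its core, or to the two together. Also open, on these data alone, is what this assay would give with an amine or a carboxylic acid in place of the 3,4-dichlorophenyl group, or with a longer chain at the same place.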